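A few compounds are considered here, and "the series" means these few. Any claim that something is new, unique, unknown or untested is made for them only; others in the source may bear on it.

Measured so far in a functional assay on HCC1937 cells (Homo sapiens) for antiproliferative activity, read by CCK-8 assay, with a stated time of 72 h; a higher number here means a weaker inhibitor, a lower number a stronger inhibitor:
- compound 1 `O=C(Nc1cccc(-c2oc3cc(-c4ccc(F)cc4)ccc3c(=O)c2O)c1)c1ccccc1F`: 10800 nM
- compound 2 `O=C(Nc1cccc(-c2oc3cc(-c4ccc(F)cc4)ccc3c(=O)c2O)c1)c1ccc(F)cc1F`: 6980 nM

Among the measured compounds shown here, compound 2 holds the lowest of the two numbers in this assay, but the single step of a 1.5-fold lower number from compound 1 to compound 2 (0.19 log units; within the scatter) stays within the scatter, so the two compounds are not separable. Compound 3 `COc1ccccc1C(=O)Nc1cccc(-c2oc3cc(-c4ccc(F)cc4)ccc3c(=O)c2O)c1` carries the change (2-methoxyphenyl in place of 2,4-difluorophenyl on a carbonyl carbon). For the measured compounds named here, the only measured step, from compound 1 to compound 2, concerns fluorine on that same ring and bears only loosely on a methoxy swap; it gives no ground to expect a step beyond the scatter. Compound 3 is therefore expected near compound 2, at an estimated 9000 nM (range 3000 nM to 30000 nM), a step of a 1.3-fold higher number from compound 2 to compound 3 (0.11 log units; within the scatter).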

Compound 3, half-maximal inhibitory concentration: 9050 nM
Compound 3: middle estimate off by 1.0-fold (0.00 log units), on the low side, within the range that was stated.
By their numbers in this assay, from the lowest: compounds 2, 3 and 1 (each within the scatter of the next).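

In this assay the change from 2,4-difluorophenyl to 2-methoxyphenyl on the carbonyl carbon gives a 1.3-fold higher number from compound 2 to compound 3 (0.11 log units; within the scatter) and methoxy in place of fluoro on an aromatic carbon gives a 1.2-fold lower number from compound 1 to compound 3 (0.08 log units; within the scatter) so neither step separates compound 3 from the fluorinated compounds. At this position, a methoxy group with its hydrogen-bond acceptor therefore reads the same as fluorine within the scatter. No measurement on hand bears on this result. Going by these compounds, whether a carboxylic acid, an amine or a pyridine ring on this carbonyl carbon would give a step beyond the scatter remains open. Changes elsewhere on the shared core also remain open.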